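This account rests on a few compounds, and the source may have more. Where it says the series, first, only, none or still open, it means among the compounds named here.

In a physicochemical assay for lipophilicity, at pH 7.4 (on this read-out higher numbers stand for higher lipophilicity and lower numbers for lower lipophilicity), compound 1 (`CCCCCCCc1c(C)nc2ccccc2c1O`) gives 3.39 and compound 2 (`Cc1nc2ccccc2c(OCc2ccccc2)c1Br`) gives 2.52 while compound 3 (`CCCCCCC/C=C/c1c(C)[nH]c2ccccc2c1=O`) gives 4.26 as the top reading so far. Compound 3 thus stands highest of the three and beyond the scatter from both others, with compound 1 nearest and compound 2 furthest.

The next compound to be read is compound 4 (`Cc1[nH]c2ccccc2c(=O)c1/C=C/c1ccc(O)cc1`), which keeps the core of compound 3 and changes one group (4-hydroxyphenyl in place of heptyl on a double-bonded chain carbon bound to a double-bonded chain carbon). In words, this is 4-hydroxyphenyl in place of heptyl on a double-bonded chain carbon bound to a double-bonded chain carbon.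

Going by the values given here, no measured pair isolates this change, so any expectation rests on an indirect comparison. Compound 1 and compound 3 both carry heptyl and both read higher than compound 2, which gives 2.52, and nothing here goes against that, although these three compounds differ in more than one place. A fall beyond the scatter is therefore expected, estimated at a number 1.46 log units lower from compound 3 to compound 4 (beyond the scatter) on the strength of that loose comparison. For compound 4 the estimate is 2.8 with an expected range from 2.2 to 3.4 pending measurement.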

Compound 4, distribution coefficient: 1.77
Beside the measured number, compound 4's estimate is 1.03 log units above it, outside the stated range (below it).
By their numbers in this assay, from the lowest: compound 4; then compound 2; then compound 1; then compound 3.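

Going by these compounds alone, on the double-bonded chain carbon bound to a double-bonded chain carbon, 4-hydroxyphenyl in place of heptyl gives a number 2.49 log units lower from compound 3 to compound 4 (beyond the scatter) in this assay, the only step so far between compounds that differ in one place, and it is large. The change keeps the heavy-atom count and the absence of net charge, so this large step comes with no change in either; what differs is that the chain of carbons gives way to an aromatic ring of carbon only, together with a hydrogen-bond donor and a hydrogen-bond acceptor. These features enter together in this one step, and no measurement on hand gives a cause for its size.

From the compounds shown here alone, what remains open is how the ring and the hydroxyl each contribute, which an unsubstituted phenyl and a heptyl chain ending in a hydroxyl at this same place would begin to separate. Also open, going by these compounds, is how far the reading at this place would move with an amine or a carboxylic acid on the ring in place of the hydroxyl, or with a longer chain in place of heptyl.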